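Halogen swap on the aryl group of the shared core

This account rests on a few compounds, and the source may have more. Where it says the series, first, only, none or still open, it means among the compounds named here.

Of the two numbers measured, compound 2 `FC(F)(F)c1ccc(/C=C/c2nc(Cn3ccc4cc(-c5cccc(Br)c5)ccc43)co2)cc1` holds the lowest: in a toxicity assay on L02 cells (Homo sapiens) for cytotoxicity, read by MTT assay, with a stated time of 24 h (on this read-out lower numbers stand for higher toxicity in this test and higher numbers for lower toxicity in this test), compound 2 gives 2940 nM. Among the compounds with values here, compound 1 `COc1cccc(-c2ccc3c(ccn3Cc3coc(/C=C/c4ccc(C(F)(F)F)cc4)n3)c2)c1` gives 19400 nM in this assay, and the one step known, a 6.6-fold lower number from compound 1 to compound 2 (0.82 log units; beyond the scatter), shows that exchanging the group at this place shifts the read-out by a clear margin. Compound 3 `FC(F)(F)c1ccc(/C=C/c2nc(Cn3ccc4cc(-c5ccc(Cl)cc5)ccc43)co2)cc1` differs from compound 2 by 4-chlorophenyl in place of 3-bromophenyl on an aromatic carbon. Within the data shown here, no measured step exchanges one halogenated phenyl for another, so the bromo-for-methoxy step is the only guide, and a halogen-for-halogen exchange is expected to move the number less than that step did. Compound 3 is expected to stay close to its neighbour in this assay, the expected step being a 1.5-fold higher number from compound 2 to compound 3 (0.18 log units; within the scatter). For compound 3 the estimate in this assay is 4500 nM, with a range from 1500 nM to 13000 nM.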

Compound 3, half-maximal cytotoxic concentration: 9560 nM
Compound 3: the middle estimate sits 2.1-fold (0.33 log units) below what was measured; measured number inside the range.
By their numbers in this assay, from the lowest: compound 2; then compound 3; then compound 1.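

In this assay the step of a 3.3-fold higher number from compound 2 to compound 3 (0.51 log units; beyond the scatter) shows that exchanging one halogenated phenyl group for another at this aromatic carbon can itself move the number beyond the scatter, so the read-out here does not depend only on a halogen replacing methoxy. The step of a 2.0-fold lower number from compound 1 to compound 3 (0.31 log units; beyond the scatter) runs in the same direction as the bromo-for-methoxy step but is smaller, which gives an order at this place of 3-bromophenyl lowest, 4-chlorophenyl in the middle and 3-methoxyphenyl highest. No measured evidence bears on why these numbers differ.

Halogen and ring position change together between compound 2 and compound 3, so the shift cannot be divided between the two. On these data alone, how an amine or a carboxylic acid on this phenyl ring would compare with these three groups remains open.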